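A few compounds are considered here, and "the series" means these few. Any claim that something is new, unique, unknown or untested is made for them only; others in the source may bear on it.

Measured so far:
compound 1, `Nc1nc(N)c2c(-c3cc4ccccc4o3)cn([C@@H]3O[C@H](CO)[C@@H](O)[C@H]3O)c2n1`: > 20000 nM (a limit)
compound 2, `Nc1nc(N)c2c(-c3ccoc3)cn([C@@H]3O[C@H](CO)[C@@H](O)[C@H]3O)c2n1`: > 20000 nM (a limit)
compound 3, `COc1ncnc2c1c(-c1ccsc1)cn2[C@@H]1O[C@H](CO)[C@@H](O)[C@H]1O`: 3450 nM

In a functional assay on K562 cells (Homo sapiens), read by MTT assay, with a stated time of 72 h (a lower number here means a stronger inhibitor, a higher number a weaker inhibitor), compound 2 gives only a limit, > 20000 nM, no number. Compound 1 likewise sits at a limit in this assay. Among the measured compounds shown here, compound 3 is the one compound with a numerical value. For the measured compounds named here, the single one-place step, a step that the two limits leave unreadable from compound 1 to compound 2, is unreadable, both ends being limits; the limit of > 20000 nM in this assay, at which 2 of the 3 values shown sit, is where two of the three values stand.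

Compound 4, `Nc1nc(N)c2c(-c3ccco3)cn([C@@H]3O[C@H](CO)[C@@H](O)[C@H]3O)c2n1`, differs from compound 2 by furan-2-yl in place of furan-3-yl on an aromatic carbon. Going by the values given here, no measured step bears on this change, and the only one-place step gives no size. Nothing therefore argues for a step beyond the scatter. Compound 4 is expected at 25000 nM, in the range 8000 nM to 80000 nM, and the expected step is a step that the limit leaves unreadable from compound 2 to compound 4.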

Compound 4, half-maximal inhibitory concentration: > 20000 nM
Compound 4 gave a limit, no number; the forecaster's own chance of this, stated with the estimate: 70%; the middle value lies beyond the limit too.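

Compound 4 joins compound 1 and compound 2 at a limit, so no new step among them can be read in this assay: the limit of > 20000 nM in this assay, at which 3 of the 4 values shown sit.

Going by these compounds, whether furan-2-yl, furan-3-yl and 1-benzofuran-2-yl differ at all on the shared core remains open.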